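The compounds below may be only part of what the source reports. "The series", "measured", "known", "first", "only" and "open" are said of these compounds alone.

In a functional assay on EC9706 cells (Homo sapiens) for cytotoxicity, read by MTT assay, with a stated time of 72 h (a higher number here means a weaker inhibitor, a lower number a stronger inhibitor), compound 1 `O=C(CSC(=S)N[C@H]1CCOC1=O)Nc1ccc(O)cc1` reaches only a limit, > 128000 nM, and not a true number. Compound 2 `CCCCc1ccc(NC(=O)CSC(=S)N[C@H]2CCOC2=O)cc1` gives 44200 nM. For the measured compounds named here, compound 3 `O=C(CCl)Nc1ccc(C(=O)/C=C/c2ccccc2)cc1`, built differently from those two, gives 6370 nM, the lowest number measured so far in this assay.

Compound 4 `O=C(CCl)Nc1ccc(C(=O)/C=C/c2cccc(Cl)c2)cc1` keeps all of compound 3 except for one position on a ring. It carries chloro in place of hydrogen on an aromatic carbon, meta to a large group, turning phenyl into 3-chlorophenyl: chloro in place of hydrogen on an aromatic carbon.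

Going by the values given here, only one measured step offers any guide, and a loose one. The step of an at least 2.8-fold lower number from compound 1 to compound 2 (0.46 log units; beyond the scatter) exchanges butyl for hydroxy on an aromatic carbon. It goes beyond the scatter, but it starts from a limit, (the limit of > 128000 nM in this assay, at which 1 of the 3 values shown sits), and it involves different groups on a different core. It shows that a new group on an aromatic carbon can shift the number in this series, but it cannot set the size of the chloro step. Among the compounds with values here, no measured pair tests chloro itself.

The expected change is therefore small and towards a lower number, and it may stay within the scatter: a 1.3-fold lower number from compound 3 to compound 4 (0.12 log units; within the scatter). For compound 4 the estimated value is 4800 nM, with an expected range of 2000 nM to 11500 nM.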

Compound 4, half-maximal inhibitory concentration: 5560 nM
Beside the measured number, compound 4's estimate is 1.2-fold (0.06 log units) below it; the range from low to high includes it.
By their numbers in this assay, from the lowest: compounds 4 and 3 (each within the scatter of the next); then compound 2. At a limit, above all of these: compound 1.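

In this assay, for the compounds shown here, chloro in place of hydrogen, turning phenyl into 3-chlorophenyl, gives a 1.1-fold lower number from compound 3 to compound 4 (0.06 log units; within the scatter) and so provides the first measured pair that tests chloro itself. The step stays within the scatter, so a chlorine atom at this carbon of the ring brings no change that can be told apart from repeat-to-repeat variation, and compounds 3 and 4 should be read as equal in this assay. The earlier compounds could not show this, as the only earlier step swaps hydroxy for butyl on a different core and starts from a limit, and no measured property shown here bears on why this position gives so little response.

Going by these compounds, one atom at one place is a narrow test, so it remains open whether a different group at this carbon, such as an amine, a carboxylic acid or a longer chain, would move the number beyond the scatter. On these data alone, it is equally open whether chloro on another carbon of this ring, or on the aromatic ring of the core shared by compounds 1 and 2, would behave the same way.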